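Aryl swap on the shared core: cytotoxicity working notes

A few compounds are considered here, and "the series" means these few. Any claim that something is new, unique, unknown or untested is made for them only; others in the source may bear on it.

Measured so far:
Compound 1 `CN1CCN(C2CCN(c3nccc4[nH]c(-c5ccc(F)c(F)c5)nc34)CC2)CC1` gives 5000 nM in an ADME assay on CHO cells (Cricetulus griseus) for cytotoxicity, read by MTT assay; on this read-out lower numbers stand for higher toxicity in this test and higher numbers for lower toxicity in this test.
Compound 2 `CN1CCN(CC2CCN(c3nccc4[nH]c(-c5ccc(F)c(F)c5)nc34)CC2)CC1` gives 7400 nM in this assay.

Compound 1 holds the lowest of the two numbers in this assay; its nearest neighbour is compound 2, and the step of a 1.5-fold higher number from compound 1 to compound 2 (0.17 log units; within the scatter) stays within the scatter. Compound 3 `COC(=O)c1cccc(-c2nc3c(N4CCC(N5CCN(C)CC5)CC4)nccc3[nH]2)c1` is not yet measured in this assay. It differs from compound 1 in one place: 3-(methoxycarbonyl)phenyl in place of 3,4-difluorophenyl on an aromatic carbon. For the measured compounds named here, the only measured step, a 1.5-fold higher number from compound 1 to compound 2 (0.17 log units; within the scatter), concerns (4-methylpiperazin-1-yl)methyl in place of 4-methylpiperazin-1-yl on a saturated ring carbon and leaves the aryl group untouched, so it does not bear on the present change. Going by the values given here, no measured pair shows what exchanging the aryl group does in this assay. The expectation therefore rests on compound 1 alone, and a step of a 1.2-fold higher number from compound 1 to compound 3 (0.08 log units; within the scatter), that is none beyond the scatter, is expected, with a wide range. For compound 3 the estimate in this assay is 6000 nM, expected to fall between 2000 nM and 18000 nM.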

Compound 3, half-maximal cytotoxic concentration: 34000 nM
Compound 3: middle estimate off by 5.7-fold (0.75 log units), on the low side, outside the stated range (above it).
By their numbers in this assay, from the lowest: compounds 1 and 2 (each within the scatter of the next); then compound 3.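

In this assay, the aromatic carbon between two ring nitrogen atoms proves sensitive to the aryl group: 3-(methoxycarbonyl)phenyl in place of 3,4-difluorophenyl gives a 6.8-fold higher number from compound 1 to compound 3 (0.83 log units; beyond the scatter), while the saturated ring carbon change, a 1.5-fold higher number from compound 1 to compound 2 (0.17 log units; within the scatter), stays within the scatter. On this single pair, the aryl exchange moves the number towards lower toxicity in this test, with the ring type and absence of net charge unchanged and the 2 hydrogen-bond acceptors of the entering group as a counted difference. No available evidence assigns this step to any feature of either group.

Still open, from the compounds shown here alone, is whether the step follows from the methyl ester or from the loss of the two fluorine atoms, which a carboxylic acid, a primary amide or an unsubstituted phenyl at this position could separate. Also open, going by these compounds, is whether the same aryl exchange holds with the (4-methylpiperazin-1-yl)methyl group of compound 2.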